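Adding a methyl where three compounds already show nothing

A few compounds are considered here, and "the series" means these few. Any claim that something is new, unique, unknown or untested is made for them only; others in the source may bear on it.

Compound 2 `Cc1nc(Nc2ccccc2)sc1C(=O)/C=C/c1ccccc1` is the simplest member of this small set. In a functional assay on PC-3 cells (Homo sapiens) for cytotoxicity, read by MTT assay (a higher number here means a weaker inhibitor, a lower number a stronger inhibitor), compound 2 gives only a limit, > 25000 nM. Compound 1 `Cc1ccccc1Nc1nc(C)c(C(=O)/C=C/c2ccccc2)s1` differs from it by methyl in place of hydrogen on an aromatic carbon, a methyl placed ortho to a large group. In this assay compound 1 also gives only a limit, > 25000 nM. The step that the two limits leave unreadable from compound 2 to compound 1 therefore cannot be read, since the limit of > 25000 nM in this assay, at which 3 of the 3 values shown sit, holds every value shown. Compound 3 `Cc1nc(Nc2ccccc2)sc1C(=O)/C=C/c1ccccc1Cl` differs from compound 2 by chloro in place of hydrogen on an aromatic carbon. In this assay compound 3 too gives only a limit, > 25000 nM. The step that the two limits leave unreadable from compound 2 to compound 3 is equally unreadable.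

Compound 4 `Cc1ccc(Nc2nc(C)c(C(=O)/C=C/c3ccccc3Cl)s2)cc1`, not yet measured, differs from compound 3 by methyl in place of hydrogen on an aromatic carbon. This is the same kind of change as from compound 2 to compound 1, but not the same: there the methyl sits ortho to a large group, here para to a large group. Because the limit of > 25000 nM in this assay, at which 3 of the 3 values shown sit, holds the values of compound 1, compound 2 and compound 3, the expected step is a step that the limit leaves unreadable from compound 3 to compound 4, in effect none. Compound 4 is expected to give about 30000 nM in this assay, most likely once more only a limit, with a range from 10000 nM to 100000 nM.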

Compound 4, half-maximal inhibitory concentration: > 25000 nM
Compound 4: no number, only a limit; the forecaster's own chance of this, stated with the estimate: 80%; the middle value is on the limit's open side.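

In this assay compound 4 also gives only a limit, > 25000 nM. The step from compound 3 to compound 4 therefore cannot be read, and neither can any other step among compounds 1 to 4: the limit of > 25000 nM in this assay, at which 4 of the 4 values shown sit.

The compounds shown leave open whether they differ at all in this assay, and whether any change to the shared core would give a value that can be read as a number.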